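This account rests on a few compounds, and the source may have more. Where it says the series, first, only, none or still open, it means among the compounds named here.

Compound 3 `Cc1ccc2c(c1)c(=O)c(C(=O)Nc1ccc(Oc3ncnc4[nH]cc(-c5ccccc5)c34)c(F)c1)cn2C`: 150 nM
Compound 2 `CCCCn1c(C)c(C(=O)Nc2ccc(Oc3ncnc4[nH]cc(-c5ccccc5)c34)c(F)c2)c(=O)c2cc(C)ccc21`: 480 nM
Compound 1 `Cc1c(C(=O)Nc2ccc(Oc3ncnc4[nH]cc(-c5ccccc5)c34)c(F)c2)c(=O)c2c(Cl)cccc2n1C`: > 10000 nM (a limit, not a number)

Of the compounds shown here, three sharing one core have been tested in an assay on isolated protein for inhibition of tyrosine-protein kinase receptor UFO (Homo sapiens), read by FRET and Z'-LYTE, with a stated time of 1.5 h; on this read-out higher numbers stand for weaker inhibition and lower numbers for stronger inhibition. Compound 3 gives 150 nM, the lowest of the two numbers reported. Compound 2 gives 480 nM, a higher number, and the gap between compound 2 and compound 3 is beyond the usual scatter. For compound 1 only a limit is known: it sits at the limit of > 10000 nM in this assay, at which 1 of the 3 values shown sits.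

The next compound, compound 4 `Cc1ccc2c(c1)c(=O)c(C(=O)Nc1ccc(Oc3ncnc4[nH]cc(-c5ccccc5)c34)c(F)c1)c(-c1ccccc1)n2C`, has not yet been measured in this assay. It differs from compound 3 in one place: phenyl in place of hydrogen on an aromatic carbon. Among the compounds with values here, no measured pair shows exactly this change, so the expectation rests on compound 3 alone. A phenyl group entering there is a sizeable addition, and the expectation is a modest rise in the number, possibly beyond the scatter, expressed as a 2.7-fold higher number from compound 3 to compound 4 (0.43 log units; beyond the scatter). For compound 4 the estimated value in this assay is 400 nM, with a range from 100 nM to 3000 nM.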

Compound 4, half-maximal inhibitory concentration: 78 nM
Compound 4: the middle estimate sits 5.1-fold (0.71 log units) above what was measured; the whole stated range lies above it.
By their numbers in this assay, from the lowest: compounds 4 and 3 (each within the scatter of the next); then compound 2. At a limit, above all of these: compound 1.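

Phenyl in place of hydrogen on this aromatic carbon, next to the ring nitrogen, gives a 1.9-fold lower number from compound 3 to compound 4 (0.28 log units; within the scatter) in this assay. Within the data shown here, this position therefore accepts a whole aromatic ring without a measurable loss of inhibition, and the earlier compounds offered no comparison that differed in one place only. This rests on a single pair, and nothing measured here explains why the ring is accepted at this position.

As far as these compounds go, it remains open whether other groups at this carbon, such as an amine, a carboxylic acid or a morpholine ring, would keep the number at this level or shift it. From the compounds shown here alone, it is also open whether an amine or a carboxylic acid attached to the new phenyl ring would move the number beyond the scatter.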